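Methoxy to ethoxy on compound 2: cytotoxicity notes

The source may report more compounds than this note shows. Statements on the series, on what has been measured and on what is new or still open speak of the compounds shown alone.

Measured in a functional assay on HepG2 cells (Homo sapiens) for cytotoxicity, read by MTT assay, with a stated time of 72 h; on this read-out lower numbers stand for stronger inhibition and higher numbers for weaker inhibition:
- compound 1 `C=C(C)[C@@H]1CC[C@](C)(O)[C@H]1/C=C/C(C)=C/[C@@H]1C[C@@]2([C@H](OC)O1)[C@H](CCCO)/C(=C(/C)C=O)CC[C@]2(C)O`: > 10000 nM (a limit)
- compound 2 `C=C(C)[C@H]1CC[C@@](C)(O)[C@@H]1/C=C/C(C)=C/[C@@H]1C[C@@]2([C@H](OC)O1)[C@H](CCCO)/C(=C(\C)C=O)CC[C@]2(C)O`: > 10000 nM (a limit)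

Compound 2 stands only at a limit, and the measured set shares it: the limit of > 10000 nM in this assay, at which 2 of the 2 values shown sit. Compound 3 `C=C(C)[C@H]1CC[C@@](C)(O)[C@@H]1/C=C/C(C)=C/[C@@H]1C[C@@]2([C@H](OCC)O1)[C@H](CCCO)/C(=C(\C)C=O)CC[C@]2(C)O` turns methoxy to ethoxy: methyl in place of hydrogen on a saturated chain carbon bound to an oxygen on a saturated carbon. Among the measured compounds shown here, the one measured step, a step that the two limits leave unreadable from compound 1 to compound 2, has no readable size and concerns configuration alone (the fact that compounds 1 and 2 differ only in the configuration as drawn), so it does not bear on this change. Compound 2 at the limit of > 10000 nM gives no number to start from, and no shift beyond the scatter is expected in this assay. The expected step is a step that the limit leaves unreadable from compound 2 to compound 3. Compound 3 is estimated at 15000 nM, within 8000 nM to 40000 nM.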

Compound 3, half-maximal inhibitory concentration: > 10000 nM
Compound 3 was reported as a limit; the forecaster's own chance of this, stated with the estimate: 85%; the middle value does not contradict the limit.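

Compound 2 and compound 3 both stand only as limits, not numbers, so no step from methoxy to ethoxy can be read: the limit of > 10000 nM in this assay, at which 3 of the 3 values shown sit.

The compounds shown leave open whether this change alters cytotoxicity at all.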